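The source may report more compounds than this note shows. Statements on the series, on what has been measured and on what is new or still open speak of the compounds shown alone.

Compound 1 `Nc1ccccc1NC(=O)CCCCCN(CC(=O)NC1CCCCC1)C(=O)c1ccccc1` and compound 2 `CN(C)c1ccc(C(=O)N(CC(=O)NCc2ccccc2)Cc2ccc(C(=O)Nc3ccccc3N)cc2)cc1` were both tested in a functional assay on A2780 cells (Homo sapiens) for cytotoxicity, read by MTT assay, with a stated time of 72 h; on this read-out higher numbers stand for weaker inhibition and lower numbers for stronger inhibition. Compound 1 gives 181000 nM, while compound 2 gives 2400 nM, the lower of the two numbers, and the gap between them lies beyond the scatter. Compound 3 `Nc1ccccc1NC(=O)c1ccc(CN(CC(=O)NCc2ccccc2)C(=O)c2cccnc2)cc1` has not yet been measured. It differs from compound 2 in one place: pyridin-3-yl in place of 4-(dimethylamino)phenyl on a carbonyl carbon. Within the data shown here, no measured pair covers this change, so the expected step of a 1.5-fold higher number from compound 2 to compound 3 (0.16 log units; within the scatter) is small, toward a somewhat higher number, and may well fall within the scatter. Compound 3 is therefore estimated at 3500 nM, with a range from 1200 nM to 10000 nM.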

Compound 3, half-maximal inhibitory concentration: 8900 nM
Compound 3: middle estimate off by 2.5-fold (0.41 log units), on the low side, and the stated range covers the measured number.
By their numbers in this assay, from the lowest: compound 2; then compound 3; then compound 1.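

Among these compounds, this is the first readable step at this position: in this assay, replacing 4-(dimethylamino)phenyl with pyridin-3-yl on the carbonyl carbon gives a 3.7-fold higher number from compound 2 to compound 3 (0.57 log units; beyond the scatter). The group here therefore changes the number, though only modestly. Nothing available explains the size or direction of this step. Going by these compounds, it remains open whether the step follows the loss of the dimethylamino group or the arrival of the ring nitrogen. A plain phenyl on this carbonyl carbon would help separate the two.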